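The source may hold more compounds than are shown below. What is called first, only, known or untested is meant among the compounds shown, and "the series" means these compounds.

Measured in a functional assay on HeLa cells (Homo sapiens) for inhibition, read by sulforhodamine B assay; on this read-out higher numbers stand for weaker inhibition and lower numbers for stronger inhibition:
- Compound 1 `O=C1C=C(NCc2ccccc2)C(=O)c2c1nc1n2[C@H]2OC[C@@H](O)[C@H]2OC1`: > 8000 nM, a limit
- Compound 2 `O=C1C(Nc2ccccc2F)=CC(=O)c2c1nc1n2[C@H]2OC[C@@H](O)[C@H]2OC1`: 9820 nM
- Compound 3 `O=C1C=C(N2CCC2)C(=O)c2c1nc1n2[C@H]2OC[C@@H](O)[C@H]2OC1`: > 16000 nM, a limit

Compound 2 is the only one of these with a number, at 9820 nM. The values of compound 1 and compound 3 are limits and not numbers.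

Compound 4 `O=C1C(Nc2ccc(Br)cc2)=CC(=O)c2c1nc1n2[C@H]2OC[C@@H](O)[C@H]2OC1` has not yet been measured. It differs from compound 2 by one change: 4-bromophenyl in place of 2-fluorophenyl on an amine nitrogen. In short, it carries 4-bromophenyl in place of 2-fluorophenyl on an amine nitrogen.

Among the measured compounds shown here, the only measured step is a step that the two limits leave unreadable from compound 1 to compound 3. That step concerns azetidin-1-yl in place of benzylamino, a different change, and it gives no size to carry over. For the measured compounds named here, no measured step therefore bears on this change, and neither a direction nor a step beyond the usual scatter can be expected. The estimate stays close to compound 2 at 9820 nM.

The expected result is a 1.2-fold lower number from compound 2 to compound 4 (0.09 log units; within the scatter). Compound 4 is estimated at 8000 nM, with an expected range of 2500 nM to 25000 nM.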

Compound 4, half-maximal inhibitory concentration: 5220 nM
Estimate against measurement, compound 4: 1.5-fold (0.19 log units) above, and the stated range covers the measured number.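

In this assay, among the compounds shown here, the change from (2-fluorophenyl)amino to (4-bromophenyl)amino gives a 1.9-fold lower number from compound 2 to compound 4 (0.27 log units; within the scatter), the first step that can be read; the only earlier step cannot be read. At this amine nitrogen, then, 4-bromophenyl and 2-fluorophenyl cannot be told apart in this assay, even though the halogen and its place on the ring differ between them. Nothing measured here offers a reason for this step.

Because both the halogen and its place change in this one step, the compounds shown cannot separate the two. On these data alone, it also remains open whether a plain phenyl, or a phenyl carrying a carboxylic acid or a longer amine chain, on this nitrogen would move the number beyond the scatter.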